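A few compounds are considered here, and "the series" means these few. Any claim that something is new, unique, unknown or untested is made for them only; others in the source may bear on it.

Measured so far:
compound 1, `COc1ccc2[nH]c(-c3ccccc3)c(/C=C(\C#N)S(=O)(=O)c3ccccc3)c2c1`, 6500 nM
compound 2, `N#C/C(=C\c1c(-c2ccccc2)[nH]c2ccccc12)S(=O)(=O)c1ccccc1`, 2600 nM

Working notes. For the measured compounds named here, in a functional assay on CCRF-CEM cells (Homo sapiens) for inhibition, read by sulforhodamine B assay, with a stated time of 48 h (a lower number here means a stronger inhibitor of growth, a higher number a weaker inhibitor of growth), compound 2 stands at the lower of the two numbers, the only other compound being compound 1 at a higher value; the single measured step is a 2.5-fold lower number from compound 1 to compound 2 (0.40 log units; beyond the scatter), which concerns a substituent on the shared core. Compound 3, `N#C/C(=C\c1c(-c2ccccc2)[nH]c2ccccc12)C(=O)c1ccccc1`, has not yet been measured. It differs from compound 2 by benzoyl in place of phenylsulfonyl on a double-bonded chain carbon bound to a double-bonded chain carbon and a triple-bonded carbon. Going by the values given here, no measured step bears on this change: the one step on record alters the core substituent and leaves the chain untouched, so it gives no guide to exchanging the group on the chain carbon. With nothing to anchor a direction, compound 3 is expected to stay near compound 2, with a wide range; the expected step is a 1.2-fold higher number from compound 2 to compound 3 (0.06 log units; within the scatter). For compound 3 in this assay the estimate is 3000 nM, between 900 nM and 10000 nM.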

Compound 3, concentration for 50% growth inhibition: 7300 nM
Compound 3: middle estimate off by 2.4-fold (0.39 log units), on the low side, and the stated range covers the measured number.
By their numbers in this assay, from the lowest: compound 2; then compounds 1 and 3 (each within the scatter of the next).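

In this assay the double-bonded chain carbon bound to a double-bonded chain carbon and a triple-bonded carbon proves sensitive to its substituent: benzoyl in place of phenylsulfonyl gives a 2.8-fold higher number from compound 2 to compound 3 (0.45 log units; beyond the scatter) and so shows that the series responds to a change on the chain as well as on the shared core. Of the two groups compared at this position, phenylsulfonyl gives the stronger growth inhibition, although the step is modest. No available evidence accounts for this difference.

The compounds shown leave open how a carboxylic acid or an amide would compare with phenylsulfonyl and benzoyl on this chain carbon. They also leave open whether methoxy on the shared core would give a similar step when benzoyl rather than phenylsulfonyl occupies the chain.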